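The source may report more compounds than this note shows. Statements on the series, on what has been measured and on what is new or still open speak of the compounds shown alone.

Two compounds define the picture so far. Compound 1 `Cc1ccc(OCC(=O)N(Cc2cccs2)c2ccncc2)cc1` is measured in an assay on HEK293 cells for agonist activity at transient receptor potential cation channel subfamily M member 8 (Homo sapiens), read by fluorescence and calcium flux, with a stated time of 15 min (a lower number here means that less compound is needed, a higher number that more compound is needed for the effect), and gives 52 nM. Compound 2 `Cc1ccc2oc(C(=O)N(Cc3cccs3)c3ccn[nH]3)cc2c1` shares the amide nitrogen bearing the thiophene-methyl arm and gives 40 nM in this assay. Of these two numbers, compound 1 sits at the upper end, but the gap to compound 2 lies within the usual scatter of repeated measurements, so the two cannot be told apart on this evidence.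

Compound 3 `CCC(C)N(Cc1cccs1)C(=O)COc1ccc(C)cc1` has not yet been measured in this assay. It differs from compound 1 in a single place: sec-butyl in place of pyridin-4-yl on an amide-type nitrogen. For the measured compounds named here, no pair among the measured compounds isolates a change of this kind, so there is no directly comparable step to lean on. Because compound 1 gives 52 nM and the replacement removes the six-membered aromatic ring and its hydrogen-bond acceptor in favour of a short saturated chain, the author expects the number for compound 3 to move upward beyond the scatter, by a step of about a 2.9-fold higher number from compound 1 to compound 3 (0.46 log units; beyond the scatter). The estimate for compound 3 in this assay is therefore 150 nM, with a likely range from 40 nM to 600 nM.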

Compound 3, half-maximal effective concentration: 2000 nM
Estimate against measurement, compound 3: 13-fold (1.12 log units) below; the measured number lies above the stated range.
By their numbers in this assay, from the lowest: compounds 2 and 1 (each within the scatter of the next); then compound 3.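

At this position the group on the amide-type nitrogen is far from interchangeable in this assay: with the rest of the molecule unchanged, sec-butyl in place of pyridin-4-yl gives a 38-fold higher number from compound 1 to compound 3 (1.59 log units; beyond the scatter), a large step well beyond the scatter. The earlier pair could not show this, since compound 1 and compound 2 differ in more than one place and their numbers lie within the scatter of each other, so neither says anything about this nitrogen substituent alone. The change replaces a six-membered aromatic ring with 1 hetero atom and 1 hydrogen-bond acceptor by a chain with no ring and no such acceptor, and no measurement at hand ties the step to any one of these differences.

The compounds shown leave open whether phenyl, a six-membered aromatic ring with no hetero atom, or cyclohexyl, a saturated ring, would stay close to compound 1 or fall towards compound 3 on this nitrogen. They also leave open whether sec-butyl would bring a step of similar size on the core of compound 2.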